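Nitroimidazole-oxadiazole series: aryl swap on the oxadiazole

A few compounds are considered here, and "the series" means these few. Any claim that something is new, unique, unknown or untested is made for them only; others in the source may bear on it.

Two compounds carry numbers in a functional assay on MCF7 cells (Homo sapiens) for cytotoxicity, read by MTT assay, with a stated time of 48 h; a lower number here means a stronger inhibitor, a higher number a weaker inhibitor. Compound 1 `Cc1ncc([N+](=O)[O-])n1CCSc1nnc(-c2ccccc2F)o1` gives 20500 nM in this assay. Compound 2 `COc1cc(OC)cc(-c2nnc(SCCn3c([N+](=O)[O-])cnc3C)o2)c1` gives 12800 nM in this assay; the two values lie within the scatter of each other, so no order between them is read. Compound 3 `Cc1ncc([N+](=O)[O-])n1CCSc1nnc(-c2ccnc(Cl)c2)o1` shares the core of compound 1 and differs in one place: 2-chloropyridin-4-yl in place of 2-fluorophenyl on an aromatic carbon. Going by the values given here, no measured pair tracks this change, so only the two known values guide the expectation. Compound 3 is expected to give 18000 nM in this assay, with a range of 8000 nM to 40000 nM. The step of a 1.1-fold lower number from compound 1 to compound 3 (0.06 log units; within the scatter) is expected to stay within the scatter, in no particular direction.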

Compound 3, half-maximal inhibitory concentration: 40500 nM
The estimate for compound 3 lay 2.3-fold (0.35 log units) below the measured number; the whole stated range lies below it.
By their numbers in this assay, from the lowest: compounds 2, 1 and 3 (each within the scatter of the next, the first and the last beyond it).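

In this assay, going by these compounds alone, the change at this aromatic carbon, 2-chloropyridin-4-yl in place of 2-fluorophenyl, gives a 2.0-fold higher number from compound 1 to compound 3 (0.30 log units; within the scatter) and is the only step read so far at this position. A ring with a hetero atom and a hydrogen-bond acceptor therefore brings no change beyond the scatter here. No evidence on hand bears on this result. Open, going by these compounds, is whether an amine or a carboxylic acid on this aryl ring would shift the number beyond the scatter, and whether the ring nitrogen or the chlorine alone would matter.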